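The compounds below may be only part of what the source reports. "The series", "measured", "known", "first", "only" and "open" are said of these compounds alone.

The series shares one core. Compound 1 `C#Cc1cn([C@@H]2O[C@H](CO)[C@@H](O)[C@H]2O)c2ncnc(OC)c12` carries an ethynyl group, compound 2 `COc1ncnc2c1c(-c1ccccc1)cn2[C@@H]1O[C@H](CO)[C@@H](O)[C@H]1O` a phenyl group, and compound 3 `COc1ncnc2c1c(-c1ccco1)cn2[C@@H]1O[C@H](CO)[C@@H](O)[C@H]1O` a furan-2-yl group on an aromatic carbon of that core. In an ADME assay on MRC5 cells (Homo sapiens), read by MTT assay, with a stated time of 72 h (on this read-out higher numbers stand for weaker inhibition and lower numbers for stronger inhibition), compound 1 reaches only the limit of the assay, > 100000 nM. In this assay compound 2 likewise stops at the limit, > 100000 nM. Compound 3 alone gives a number in this assay, 1700 nM. It stands as the one measured point among three, while compound 1 and compound 2 sit at the limit (the limit of > 100000 nM in this assay, at which 2 of the 3 values shown sit). The steps to it are large: an at least 58-fold lower number from compound 1 to compound 3 (1.76 log units; beyond the scatter) and an at least 58-fold lower number from compound 2 to compound 3 (1.76 log units; beyond the scatter). The step between compound 1 and compound 2 cannot be read, a step that the two limits leave unreadable from compound 1 to compound 2.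

Compound 4 `COc1ncnc2c1c(-c1ccsc1)cn2[C@@H]1O[C@H](CO)[C@@H](O)[C@H]1O` differs from compound 3 in one place: thiophen-3-yl in place of furan-2-yl on an aromatic carbon. Going by the values given here, both measured steps that bear on this point replaced another group with furan-2-yl and lowered the number sharply; the reverse move away from furan-2-yl gives no direct precedent for thiophen-3-yl. A moderately higher number is therefore expected for compound 4 in this assay, as a 2.9-fold higher number from compound 3 to compound 4 (0.47 log units; beyond the scatter), with the estimate 5000 nM and a range from 1000 nM to 40000 nM.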

Compound 4, half-maximal inhibitory concentration: 75300 nM
Compound 4: the middle estimate sits 15-fold (1.18 log units) below what was measured; measured number above the stated range.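

In this assay, this position does not treat thiophen-3-yl and furan-2-yl alike, although both are five-membered aromatic rings with 1 hetero atom and the same heavy-atom count: the result is a 44-fold higher number from compound 3 to compound 4 (1.65 log units; beyond the scatter). Among the two such rings shown, the low number therefore goes with furan-2-yl alone, not with this ring type in general. The other two comparisons are an at least 1.3-fold lower number from compound 2 to compound 4 (0.12 log units; that floor lies within the scatter) and an at least 1.3-fold lower number from compound 1 to compound 4 (0.12 log units; that floor lies within the scatter), and neither shows how far compound 4 truly lies from those compounds: the limit of > 100000 nM in this assay, at which 2 of the 4 values shown sit.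

The compounds shown leave open whether the sulfur or the point of attachment carries the large step, since both change at once in this pair, and a thiophen-2-yl group would separate them. They also leave open how an amine or a longer chain would read at this position.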